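Working notes: thione series, nitro for bromo step

This account rests on a few compounds, and the source may have more. Where it says the series, first, only, none or still open, it means among the compounds named here.

Measured so far:
compound 1 `COc1ccc(-n2c(Nc3nc(-c4ccc([N+](=O)[O-])cc4)cs3)n[nH]c2=S)cc1` — 300 mg/kg
compound 2 `COc1ccc(-n2c(Nc3nc(-c4ccccc4)cs3)n[nH]c2=S)cc1` — 300 mg/kg
compound 3 `Cc1ccccc1-n1c(Nc2nc(-c3ccc(Br)cc3)cs2)n[nH]c1=S` — 300 mg/kg

In a functional assay on the whole organism (strain Swiss albino) for inhibition, with Mus musculus as the target, with a stated time of 4 h (on this read-out lower numbers stand for an effect already at smaller amounts and higher numbers for an effect only at larger amounts of compound), compound 1 gives 300 mg/kg. Compound 2 gives 300 mg/kg and compound 3 gives 300 mg/kg. Compound 3 thus stands level with compounds 1 and 2 at the digits shown; its nearest neighbour on the numbers is compound 1, its furthest compound 2, and neither gap leaves the scatter.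

Among the compounds with values here, only one single-point step has been measured: no change at the digits printed from compound 1 to compound 2 (within the scatter), hydrogen in place of nitro on an aromatic carbon, with no change within the scatter.

Compound 4 `Cc1ccccc1-n1c(Nc2nc(-c3ccc([N+](=O)[O-])cc3)cs2)n[nH]c1=S` has not been measured in this assay. It differs from compound 3 as follows: nitro in place of bromo on an aromatic carbon Cut one bond further out, the change reads 4-bromophenyl to 4-nitrophenyl.

The step from compound 1 to compound 2 is the only one that bears on it, since it too places or removes nitro on this aromatic carbon; it was flat. Within the data shown here, no measured step removes bromo. The shared core is otherwise unchanged. The expectation for this assay is therefore no step beyond the scatter. Compound 4 is expected to give 300 mg/kg, within the range 150 mg/kg to 600 mg/kg. The expected step of no change at the digits printed from compound 3 to compound 4 (within the scatter) lies within the scatter.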

Compound 4, minimum effective dose: 300 mg/kg
For compound 4 middle estimate and measured number coincide at the digits printed; the measured number falls inside the stated range.
By their numbers in this assay, from the lowest: compounds 1, 2, 3 and 4 (each within the scatter of the next).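

At this place, on an aromatic carbon para to a large group, nitro in place of bromo gives no change at the digits printed from compound 3 to compound 4 (within the scatter) in this assay, which adds a comparison between two substituents to the earlier step with hydrogen, no change at the digits printed from compound 1 to compound 2 (within the scatter), taken with a different aryl group on the aromatic nitrogen. Compound 4 also opens a second place to comparison: 2-methylphenyl in place of 4-methoxyphenyl on the aromatic nitrogen gives no change at the digits printed from compound 1 to compound 4 (within the scatter), so with the 4-nitrophenyl group held constant this exchange leaves the read-out flat as well. Nothing at hand accounts for the absence of a step at either place.

Hydrogen, bromo and nitro all read alike at the first place, leaving open whether an amine or a carboxylic acid there would separate from them in this assay. Also open, on these data alone, is whether a longer chain in place of the aryl group on the aromatic nitrogen would give any step, and whether the two places would act independently once either one moves the minimum effective dose.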